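Methyl for fluoro in a barely active series

The compounds below may be only part of what the source reports. "The series", "measured", "known", "first", "only" and "open" are said of these compounds alone.

In a functional assay on BGC-823 cells (Homo sapiens) for inhibition, read by MTT assay, with a stated time of 72 h (on this read-out higher numbers stand for weaker inhibition and lower numbers for stronger inhibition), compound 1 `O=C(NCc1ccc(NC(=O)c2cccc(F)c2N2CCCC2)cc1)OCc1cccnc1` gives no number, only a limit of the assay, > 100000 nM. Compound 3 `COc1ccc(N2CCCC2)c(C(=O)Nc2ccc(CNC(=O)OCc3cccnc3)cc2)c1` likewise returns only a limit, > 100000 nM. Compound 2 `O=C(NCc1ccc(NC(=O)c2ccc(F)cc2N2CCCC2)cc1)OCc1cccnc1` is the only one of the three with a number, 74500 nM. Compound 1 thus stands at the limit of > 100000 nM in this assay, at which 2 of the 3 values shown sit. Compound 4 `Cc1cccc(C(=O)Nc2ccc(CNC(=O)OCc3cccnc3)cc2)c1N1CCCC1` has methyl in place of fluoro on an aromatic carbon, ortho to a pyrrolidin-1-yl group (methyl in place of fluoro on an aromatic carbon). Among the compounds with values here, no measured pair shows what this exchange does, so no change beyond the scatter is expected in this assay, and the estimated step is a number no higher from compound 1 to compound 4 (the limit leaves the size open). For compound 4 the estimate is 100000 nM, with an expected range from 50000 nM to 200000 nM.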

Compound 4, half-maximal inhibitory concentration: > 100000 nM
Compound 4: only a limit was reported; the forecaster's own chance of this, stated with the estimate: 65%; the middle value lies on the limit itself.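

In this assay compound 4 gives only a limit, > 100000 nM. Compound 1 also gives only a limit, so no step can be read between these two compounds. From the compounds shown here alone, what methyl in place of fluoro does in this assay remains open.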